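The compounds below may be only part of what the source reports. "The series", "measured", "known", "first", "only" and "open" are said of these compounds alone.

Compound 2, `COc1cc2ncnc(Nc3ccc(Cl)c(C(F)(F)F)c3)c2cc1OCCCN1CCNCCNCC1`, gives 2980 nM in a functional assay on A-431 cells (Homo sapiens) for antiproliferative activity, read by MTT assay, with a stated time of 72 h; on this read-out lower numbers stand for stronger inhibition and higher numbers for weaker inhibition. Among the compounds with values here, that is the highest of the two numbers measured so far; the other compound, compound 1, `COc1cc2ncnc(Nc3ccc(Br)cc3F)c2cc1OCCCN1CCNCCNCC1`, gives 561 nM, and the only measured step that changes the group on the nitrogen on the aromatic ring, a 5.3-fold higher number from compound 1 to compound 2 (0.73 log units; beyond the scatter), shows that exchanging one substituted phenyl for another at this position can move the number well beyond the scatter.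

Compound 3, `COc1cc2ncnc(Nc3cccc(I)c3)c2cc1OCCCN1CCNCCNCC1`, has not yet been measured. It differs from compound 2 in one place: 3-iodophenyl in place of 4-chloro-3-(trifluoromethyl)phenyl on a nitrogen on an aromatic ring. Within the data shown here, this puts a single halogen-bearing phenyl back on that nitrogen, closer in kind to the group on compound 1 than to the one on compound 2.

Among the measured compounds shown here, only one measured step bears on this change, and it points toward a lower number when the 4-chloro-3-(trifluoromethyl)phenyl is absent. Compound 3 is therefore expected to give a step of about a 5.0-fold lower number from compound 2 to compound 3 (0.70 log units; beyond the scatter), a drop of roughly the size seen between compound 1 and compound 2, though a single prior step leaves wide uncertainty. The estimate for compound 3 in this assay is 600 nM, with a range from 150 nM to 2500 nM.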

Compound 3, half-maximal inhibitory concentration: 2220 nM
For compound 3 the middle estimate is 3.7-fold (0.57 log units) below the measured one; the measured number falls inside the stated range.
By their numbers in this assay, from the lowest: compound 1; then compounds 3 and 2 (each within the scatter of the next).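

In this assay the exchange of 4-chloro-3-(trifluoromethyl)phenyl for 3-iodophenyl on the nitrogen gives a 1.3-fold lower number from compound 2 to compound 3 (0.13 log units; within the scatter) and so does not separate these two groups, although they differ in their halogens and in the trifluoromethyl group. The change to 3-iodophenyl from the 4-bromo-2-fluorophenyl of compound 1 gives a 4.0-fold higher number from compound 1 to compound 3 (0.60 log units; beyond the scatter) and shows that a single halogen on the phenyl does not by itself bring the number close to that of compound 1, which is the strongest of the three in this test. No measurement at hand gives a reason for these numbers.

The three phenyl groups differ from one another in more than one respect, so the compounds shown leave open whether the result depends on the particular halogen, on where it sits on the ring, or on the fluorine of compound 1. A plain phenyl, a 4-bromophenyl or a 3-chlorophenyl on the same nitrogen would help to separate these possibilities, one change at a time.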